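Methoxy to hydrogen, repeated on a second core

This account rests on a few compounds, and the source may have more. Where it says the series, first, only, none or still open, it means among the compounds named here.

In a functional assay on SK-MEL-28 cells (Homo sapiens) for cytotoxicity, read by sulforhodamine B assay, with a stated time of 48 h, tested at 100 uM (on this read-out lower numbers stand for a stronger effect and higher numbers for a weaker effect at the one concentration tested), compound 1 `COc1cc(-c2cc(/C=C/C(=O)c3ccc(N)cc3)[nH]n2)cc(OC)c1OC` gives -83%. Compound 2 `COc1ccc(-c2cc(/C=C/C(=O)c3ccc(N)cc3)[nH]n2)cc1OC` carries hydrogen in place of methoxy on an aromatic carbon and in this assay compound 2 gives -93%, the step being a number 10 percentage points lower from compound 1 to compound 2 (within the scatter). Compound 3 `COc1cc(C(=O)/C=C/c2cc(-c3cc(OC)c(OC)c(OC)c3)n[nH]2)cc(OC)c1OC` rests on a core whose difference from that of compound 1 is not broken down here; in this assay compound 3 gives -97%, within the scatter of compound 2 and beyond it only against compound 1. Compound 4 `COc1ccc(-c2cc(/C=C/C(=O)c3cc(OC)c(OC)c(OC)c3)[nH]n2)cc1OC` is not yet measured; it differs from compound 3 by hydrogen in place of methoxy on an aromatic carbon, the same change as from compound 1 to compound 2, at a place described in the same words. For compound 4 the expected step in this assay is a number 2 percentage points higher from compound 3 to compound 4 (within the scatter), which rests on the earlier step of a number 10 percentage points lower from compound 1 to compound 2 (within the scatter) having stayed within the scatter. Compound 4 is therefore estimated at -95% in this assay, between -105% and -80%.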

Compound 4, a percentage reported as activity, at one concentration (the size of the read-out at that concentration, not a potency): -82%
Compound 4: middle estimate off by 13 percentage points, on the low side; measured number inside the range.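

In this assay, putting hydrogen in place of methoxy on the core of compound 3 gives a step of a number 15 percentage points higher from compound 3 to compound 4 (beyond the scatter). The same change does not carry over as one shift between the two cores: the same change on two cores in this assay, a number 10 percentage points lower (within the scatter) from compound 1 to compound 2 and a number 15 percentage points higher (beyond the scatter) from compound 3 to compound 4, 25 percentage points apart, beyond the scatter of two such steps. This rests on a single pair per core at one concentration, so it shows that the outcome of the change differed on these two cores, but it gives no rule for other cores and no cause for the difference.

The compounds shown leave open how a hydroxyl group or a fluorine atom in place of the methoxy would read on either core. They also leave open which of the two steps, if either, the same change would follow on a further core.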